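Ethoxycarbonyl in place of methyl on a urea scaffold

This account rests on a few compounds, and the source may have more. Where it says the series, first, only, none or still open, it means among the compounds named here.

Compound 1 `Cc1cccc(NC(=O)N[C@H](C)c2ccccc2)c1` was tested in an ADME assay on the whole organism with Oryza sativa as the target, tested at 0.1 uM (on this read-out higher numbers stand for a weaker effect at the one concentration tested and lower numbers for a stronger effect), and gives 100%. It stands level with compound 3 `CCCCCc1ccc(NC(=O)N[C@H](C)c2ccccc2)cc1`, which gives 100%, and the two are together the highest of the three numbers. Compound 2 `Cc1cccc(NC(=O)N[C@@H](C)c2ccccc2)c1`, which gives 99%, sits within the scatter of both. Going by the values given here, the only step between compounds that differ in one place is a number 1 percentage points lower from compound 1 to compound 2 (within the scatter); given (the fact that compounds 1 and 2 differ only in the configuration as drawn), that step says nothing about what a new substituent on the aromatic ring would do.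

Compound 4 `CCOC(=O)c1cccc(NC(=O)N[C@H](C)c2ccccc2)c1` carries the change (ethoxycarbonyl in place of methyl on an aromatic carbon). Among the compounds with values here, no measured step shows a substituent on that ring being swapped, so the only guide is that every compound so far, whatever its substituent or configuration, sits at the top of the scale. Compound 4 is therefore expected to show a number 3 percentage points lower from compound 1 to compound 4 (within the scatter), a step no larger than the scatter. The estimate for compound 4 is 97%, with a range from 85% to 100%.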

Compound 4, a percentage reported as activity, at one concentration (the size of the read-out at that concentration, not a potency): 99%
For compound 4 the middle estimate is 2 percentage points below the measured one; low and high end bracket the measured number.
By their numbers in this assay, from the lowest: compounds 2, 4, 1 and 3 (each within the scatter of the next).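

Going by these compounds alone, measured in this assay on compounds that differ in one place, ethoxycarbonyl in place of methyl on an aromatic carbon gives a number 1 percentage points lower from compound 1 to compound 4 (within the scatter) and is the first measured step that swaps a substituent on this ring. This position therefore accepts a group with more heavy atoms, two hydrogen-bond acceptors and a double bond outside the ring without a step beyond the scatter, at the one concentration tested. Nothing given here explains the size of this step.

As far as these compounds go, whether any group at this position can move the number beyond the scatter remains open, as all four compounds lie within the scatter of their neighbours. A carboxylic acid or an amine in place of the ethoxycarbonyl could test this, and so could the same ester on the opposite configuration of the stereocentre.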